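The source may report more compounds than this note shows. Statements on the series, on what has been measured and on what is new or still open speak of the compounds shown alone.

Compound 2 `O=C(O)Cc1sc(Cc2ccccc2)nc1-c1ccc(Cl)cc1` stands, together with compound 1 `O=C(O)Cc1sc(Cc2ccccc2-c2ccccc2)nc1-c1ccc(Cl)cc1`, at the lowest level of the three numbers: in an in vitro functional assay on HEK285-7 cells for antagonist activity at prostaglandin D2 receptor 2 (Homo sapiens), read by BRET and beta-arrestin recruitment (on this read-out lower numbers stand for smaller maximal responses and higher numbers for larger maximal responses), compound 2 gives 50%, and compound 1 gives 50%, so that no change at the digits printed from compound 1 to compound 2 (within the scatter). Compound 3 `O=C(O)Cc1sc(C(c2ccccc2)c2ccc(F)cc2)nc1-c1ccc(Cl)cc1` gives 80%, with a number 30 percentage points higher from compound 2 to compound 3 (beyond the scatter). Compound 4 `O=C(O)Cc1sc(NCc2ccccc2)nc1-c1ccc(Cl)cc1` differs from compound 2 in one place: benzylamino in place of benzyl on an aromatic carbon. Both measured steps alter the same substituent, the benzyl group: no change at the digits printed from compound 1 to compound 2 (within the scatter), while a number 30 percentage points higher from compound 2 to compound 3 (beyond the scatter). Within the data shown here, neither of them swaps a carbon for a nitrogen, so the new change has no direct precedent; the small rise seen for compound 3 in a number 30 percentage points higher from compound 2 to compound 3 (beyond the scatter) required a second aromatic ring, which compound 4 does not gain. Compound 4 is therefore expected to show no change at the digits printed from compound 2 to compound 4 (within the scatter), an estimated 50%, within 30% to 75%.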

Compound 4, largest response reached (reported as efficacy), in percent of the reference or control that the assay uses: 30%
The estimate for compound 4 lay 20 percentage points above the measured number; the range from low to high includes it.
By their numbers in this assay, from the lowest: compound 4; then compounds 1 and 2 (each within the scatter of the next); then compound 3.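

In this assay, among these compounds, this position on the aromatic carbon, next to the ring nitrogen and the ring sulfur, also allows a fall: benzylamino in place of benzyl gives a number 20 percentage points lower from compound 2 to compound 4 (beyond the scatter) and is the first downward step beyond the scatter. The entering group keeps its one six-membered aromatic ring but adds a hydrogen-bond donor and acceptor. Nothing available here accounts for the fall. From the compounds shown here alone, it remains open whether an ether oxygen or an amide linker would behave like the amine, and whether a 4-fluorophenyl group on the benzylamino chain carbon would bring a rise like that seen for compound 3.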